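Series notes: ring substituent next to the carboxy group

This account rests on a few compounds, and the source may have more. Where it says the series, first, only, none or still open, it means among the compounds named here.

Measured compounds:
compound 1 `O=C(O)c1ccn(Cc2cc(Br)ccc2OCc2ccccc2)n1` in an assay on CHO-K1 cells for displacement of a labelled ligand from prostaglandin E2 receptor EP1 subtype (Homo sapiens) (on this read-out higher numbers stand for weaker inhibition and lower numbers for stronger inhibition), gives 9.77 nM
compound 2 `Cc1cn(Cc2cc(Br)ccc2OCc2ccccc2)nc1C(=O)O` in this assay gives 427 nM

Compound 1 holds the lowest number of the two measured; compound 2 sits far from it, with a 44-fold higher number from compound 1 to compound 2 (1.64 log units; beyond the scatter). Among the compounds with values here, the one measured step therefore says that a substituent on this ring carbon weakens displacement strongly.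

Compound 3 `O=C(O)c1nn(Cc2cc(Br)ccc2OCc2ccccc2)cc1CO` differs from compound 1 by hydroxymethyl in place of hydrogen on an aromatic carbon. The hydroxymethyl enters the ring carbon that the methyl of compound 2 occupies, so the step from compound 1 to compound 2 is the one that bears on it. A weakening of roughly the same size is expected, because a 44-fold higher number from compound 1 to compound 2 (1.64 log units; beyond the scatter) shows the cost of a substituent there; whether the hydroxyl alters that cost cannot be told from the measured pair.

Compound 3 is therefore expected to read 300 nM, range 60 nM to 1500 nM, a step of a 31-fold higher number from compound 1 to compound 3 (1.49 log units; beyond the scatter) from compound 1.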

Compound 3, half-maximal inhibitory concentration: 676 nM
Compound 3: middle estimate off by 2.3-fold (0.35 log units), on the low side, and the stated range covers the measured number.
By their numbers in this assay, from the lowest: compound 1; then compounds 2 and 3 (each within the scatter of the next).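

In this assay hydroxymethyl on this aromatic carbon also weakens displacement, with a 69-fold higher number from compound 1 to compound 3 (1.84 log units; beyond the scatter) showing that the loss seen with methyl is not confined to that one group. Hydroxy in place of hydrogen on the methyl carbon gives a 1.6-fold higher number from compound 2 to compound 3 (0.20 log units; within the scatter) and so recovers none of that loss, leaving compounds 2 and 3 indistinguishable here. The data show the cost of these two groups but offer no measurement that explains it.

Still open, on these data alone, is whether any group on this ring carbon keeps the number close to that of compound 1, for instance a fluorine atom, an amine or a longer chain such as ethyl. Also open, as far as these compounds go, is whether the same cost appears when other parts of the core of compound 1 are changed.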